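This account rests on a few compounds, and the source may have more. Where it says the series, first, only, none or still open, it means among the compounds named here.

Measured so far:
compound 1, `CC(C)(C)Cc1csc(N)c1C(=O)c1ccc(Cl)c(Cl)c1`, giving 1%
compound 2, `CC(C)(C)Cc1c(Br)sc(N)c1C(=O)c1ccc(Cl)c(Cl)c1`, giving 1%
compound 3, `COc1ccc(-c2sc(N)c(C(=O)c3cccc(Cl)c3)c2CC(C)(C)C)cc1`, giving 1%

All three were tested in an assay on CHO cells for displacement of a labelled ligand from adenosine receptor A1 (Homo sapiens), read by scintillation counting, tested at 10 uM (on this read-out lower numbers stand for less inhibition and higher numbers for more inhibition at the one concentration tested (going by the name of the read-out)), and none of them displaces much of the labelled ligand. Going by the values given here, the one measured step between neighbours, bromo in place of hydrogen on an aromatic carbon, gave no change at the digits printed from compound 1 to compound 2 (within the scatter). Compound 3 stands level with compound 1 and compound 2 at the digits shown; its nearest neighbour by number is compound 1 and its furthest is compound 2, both within the scatter.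

The step now followed leads from compound 3 to compound 4, `COc1ccc(-c2sc(N)c(C(=O)c3ccc(Cl)c(Cl)c3)c2CC(C)(C)C)cc1`. The change is chloro in place of hydrogen on an aromatic carbon. In terms of the whole ring, a 3-chlorophenyl becomes a 3,4-dichlorophenyl. Among the compounds with values here, no measured step covers this exact change, but compound 1 and compound 2 already carry a 3,4-dichlorophenyl and each gives a low reading in this assay, while the only recorded halogen step was flat. Nothing among the numbers points upward. The expected step is therefore a number 1 percentage points higher from compound 3 to compound 4 (within the scatter), that is, none beyond the scatter.

For compound 4 in this assay the estimate is 2%, expected to fall between 0% and 12%.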

Compound 4, a percentage reported as inhibition, at one concentration (the size of the read-out at that concentration, not a potency): 1%
Estimate against measurement, compound 4: 1 percentage points above; low and high end bracket the measured number.
By their numbers in this assay, from the lowest: compounds 1, 2, 3 and 4 (each within the scatter of the next).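

In this assay, a chloro group in place of hydrogen, ortho to a chloro group and para to a large group, turns 3-chlorophenyl into 3,4-dichlorophenyl and gives no change at the digits printed from compound 3 to compound 4 (within the scatter), so this ring position, which the earlier step did not touch, shows no response to the change. With the 3,4-dichlorophenyl held fixed, a 4-methoxyphenyl group gives no change at the digits printed from compound 1 to compound 4 (within the scatter) when it replaces hydrogen and no change at the digits printed from compound 2 to compound 4 (within the scatter) when it replaces bromo, so hydrogen, bromo and 4-methoxyphenyl at that carbon cannot be told apart in this read-out. Nothing available explains why the readings stay this low.

All four compounds give low readings. Going by these compounds alone, these flat steps show only that the changes tried do not raise the number, not that the two positions could never matter. From the compounds shown here alone, it remains open whether an amine or a carboxylic acid on either aromatic ring, or a longer chain on the core, would bring any displacement of the labelled ligand at all.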